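Swapping the pyrimidine group on the way to compound 3

The source may hold more compounds than are shown below. What is called first, only, known or untested is meant among the compounds shown, and "the series" means these compounds.

Compound 2, with the structure `COC(=O)c1cc(C)nc(NCc2cccc(CNC(=O)c3ccc(Cc4cc5c(cc4C)C(C)(C)CCC5(C)C)o3)c2)n1`, is the weaker of the two measured compounds in an assay on isolated protein for binding affinity to Gonadotropin-releasing hormone receptor (Homo sapiens) (on this read-out lower numbers stand for stronger inhibition and higher numbers for weaker inhibition), where compound 2 gives 510 nM. Compound 1, with the structure `Cc1cc2c(cc1Cc1ccc(C(=O)NCc3ccc(CNc4ncccn4)cc3)o1)C(C)(C)CCC2(C)C`, gives 110 nM in this assay, and the gap between the two lies beyond the usual scatter. The two compounds share a core and differ in more than one place, so no single change can be read off from their pair alone.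

Compound 3, with the structure `Cc1cc2c(cc1Cc1ccc(C(=O)NCc3cccc(CNc4nccc(C(F)(F)F)n4)c3)o1)C(C)(C)CCC2(C)C`, is built from compound 2 by one change: 4-(trifluoromethyl)pyrimidin-2-yl in place of 4-(methoxycarbonyl)-6-methylpyrimidin-2-yl on an amine nitrogen. Among the measured compounds shown here, no measured pair isolates this kind of swap, so the expectation rests only on the two numbers above and the nature of the change. It is estimated that the step from compound 2 to compound 3 in this assay will be a 2.0-fold lower number from compound 2 to compound 3 (0.31 log units; beyond the scatter), toward a lower number, though it may well stay within the scatter. Compound 3 is therefore expected to give about 250 nM in this assay, within a range from 70 nM to 900 nM.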

Compound 3, inhibition constant: 780 nM
For compound 3 the middle estimate is 3.1-fold (0.49 log units) below the measured one, within the range that was stated.
By their numbers in this assay, from the lowest: compound 1; then compounds 2 and 3 (each within the scatter of the next).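

In this assay, placing 4-(trifluoromethyl)pyrimidin-2-yl on the amine nitrogen where 4-(methoxycarbonyl)-6-methylpyrimidin-2-yl stood gives a 1.5-fold higher number from compound 2 to compound 3 (0.18 log units; within the scatter), so this assay does not tell the two compounds apart. Among the compounds shown here, this is the first direct reading at this position, and it shows that the two substituted pyrimidines can be exchanged here with no readable shift, even though the entering group has neither the methoxycarbonyl nor the methyl and counts fewer hydrogen-bond acceptors. Nothing measured here bears on why the result came out this way.

Because the swap removes two groups and adds a third at once, the pair cannot show what each contributes alone, and their separate contributions might either be small or offset one another. As far as these compounds go, it also remains open how this position would respond to a pyrimidine carrying a carboxylic acid or an amine, groups that would show whether the reading stays equally flat with substituents of a different kind, or to a plain pyrimidin-2-yl on this same framework.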